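Replacing an acyclic amine by a substituted pyrrolidine

The compounds below may be only part of what the source reports. "The series", "measured", "known", "first", "only" and "open" are said of these compounds alone.

Compound 1 `CN(c1ccc2cc(NC(=O)CCc3ccc(C(F)(F)F)cc3)ccc2n1)C1CCCCC1` gives 1200 nM in a functional assay on HEK293 cells for activation of melanin-concentrating hormone receptor 1 (Rattus norvegicus), read by inositol phosphate accumulation (on this read-out higher numbers stand for an effect only at larger amounts of compound and lower numbers for an effect already at smaller amounts), the highest of the three numbers measured here. Compound 2 `O=C(CCc1ccc(C(F)(F)F)cc1)Nc1ccc2nc(N3CCC4(CCNC4)C3)ccc2c1` gives 140 nM, and compound 3 `O=C(CCc1ccc(C(F)(F)F)cc1)Nc1ccc2nc(N3CCCCC3)ccc2c1` gives 110 nM. Compound 4 `CNC(=O)NC1CCN(c2ccc3cc(NC(=O)CCc4ccc(C(F)(F)F)cc4)ccc3n2)C1` has not yet been measured; it differs from compound 1 in that (3-((methylcarbamoyl)amino)pyrrolidin-1-yl in place of cyclohexyl(methyl)amino on an aromatic carbon). The two measured steps that leave compound 1 bear directly on this change: both exchange cyclohexyl(methyl)amino for a ring-bound amine, and both lower the number well beyond the scatter, an 8.6-fold lower number from compound 1 to compound 2 (0.93 log units; beyond the scatter) and an 11-fold lower number from compound 1 to compound 3 (1.04 log units; beyond the scatter). Between the two ring-bound amines the difference is small, a 1.3-fold lower number from compound 2 to compound 3 (0.10 log units; within the scatter). Since the 3-((methylcarbamoyl)amino)pyrrolidin-1-yl group of compound 4 is again a ring-bound amine on the same aromatic carbon, a lowering of similar size is expected, an 8.0-fold lower number from compound 1 to compound 4 (0.90 log units; beyond the scatter). Compound 4 is therefore estimated at 150 nM, with a range from 50 nM to 500 nM.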

Compound 4, half-maximal effective concentration: 30 nM
For compound 4 the middle estimate is 5.0-fold (0.70 log units) above the measured one; the measured number lies below the stated range.
By their numbers in this assay, from the lowest: compound 4; then compounds 3 and 2 (each within the scatter of the next); then compound 1.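

In this assay, the step at this aromatic carbon next to the ring nitrogen proves larger with the new group than with either earlier ring-bound amine, giving a 40-fold lower number from compound 1 to compound 4 (1.60 log units; beyond the scatter). The result therefore reflects more than the loss of cyclohexyl(methyl)amino: the 3-((methylcarbamoyl)amino)pyrrolidin-1-yl group also separates from the two groups that had stayed within the scatter of each other, with a 3.7-fold lower number from compound 3 to compound 4 (0.56 log units; beyond the scatter) and a 4.7-fold lower number from compound 2 to compound 4 (0.67 log units; beyond the scatter). Nothing measured here accounts for this difference.

The compounds shown leave open how much of the change belongs to the five-membered ring and how much to the methylcarbamoyl group on it. Plain pyrrolidin-1-yl and 3-aminopyrrolidin-1-yl at the same position would separate those two parts.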